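Neopentyl in place of pyridin-3-yl

The source may hold more compounds than are shown below. What is called first, only, known or untested is meant among the compounds shown, and "the series" means these compounds.

In an ADME assay on 2209-23 cells (Homo sapiens) for cytotoxicity, read by WST assay (a lower number here means that less compound is tolerated, a higher number that more compound is tolerated), compound 2 `CS(=O)(=O)Nc1ccc2c(c1)S(=O)(=O)C=C(c1c(O)c3cc(F)ccc3n(Cc3cccnc3)c1=O)N2` gives > 50000 nM, which is a limit and not a number. Compound 1 `Cc1cc(Cn2c(=O)c(C3=CS(=O)(=O)c4cc(NS(C)(=O)=O)ccc4N3)c(O)c3cc(F)ccc32)ccc1F` gives > 50000 nM, also a limit. For the measured compounds named here, the only measured step at this place, a step that the two limits leave unreadable from compound 1 to compound 2, offers no size to carry over, and what stands behind it is the limit of > 50000 nM in this assay, at which 2 of the 2 values shown sit. Compound 3 `CC(C)(C)CCn1c(=O)c(C2=CS(=O)(=O)c3cc(NS(C)(=O)=O)ccc3N2)c(O)c2cc(F)ccc21` differs from compound 2 by neopentyl in place of pyridin-3-yl on a saturated chain carbon bound to an aromatic nitrogen, with neopentyl in place of pyridin-3-yl on a saturated chain carbon bound to an aromatic nitrogen. The expected step, a number no higher from compound 2 to compound 3 (the limit leaves the size open), is estimated to lie within the scatter, with no direction expected. Compound 3 is expected at 50000 nM, within an estimated range of 25000 nM to 100000 nM.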

Compound 3, half-maximal cytotoxic concentration: > 50000 nM
Compound 3: only a limit was reported; the forecaster's own chance of this, stated with the estimate: 70%; the middle value lies on the limit itself.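

No step among compound 1, compound 2 and compound 3 can be read in this assay, as each result is only a limit: the limit of > 50000 nM in this assay, at which 3 of the 3 values shown sit.

The compounds shown leave open how much compound is actually tolerated in each case, and whether exchanging these groups changes it at all.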